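The source may hold more compounds than are shown below. What is called first, only, known or untested is meant among the compounds shown, and "the series" means these compounds.

Of the compounds shown here, two have so far been measured in an ADME assay on MT2 cells (Homo sapiens) for cytotoxicity, read by MTT assay; on this read-out lower numbers stand for higher toxicity in this test and higher numbers for lower toxicity in this test. Compound 1, `Fc1cccc(F)c1Cc1cnc(Nc2ccc(-c3ccncc3)c(Cl)c2)o1`, gives 9300 nM in this assay. Compound 2, `Clc1cccc(Cl)c1Cc1nnc(Nc2ccc(COCc3ccoc3)cc2)o1`, gives 21000 nM in this assay, which is the higher of the two numbers; its nearest neighbour is compound 1, and the gap between them lies beyond the usual scatter of this assay. Among the compounds with values here, since the two compounds differ in more than one place, no single step between measured compounds can be read from them.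

Compound 3, `Clc1cccc(Cl)c1Cc1nnc(Nc2ccc(COCc3ccccn3)cc2)o1`, has not yet been measured in this assay. It differs from compound 2 in one place: pyridin-2-yl in place of furan-3-yl on a saturated chain carbon bound to an oxygen on a saturated carbon. Within the data shown here, no measured step exists for a change of this kind, so the expectation for compound 3 rests on the value of compound 2, 21000 nM, and on the change itself. The step from compound 2 to compound 3 is expected to be a 1.1-fold lower number from compound 2 to compound 3 (0.02 log units; within the scatter), that is, none beyond the scatter in either direction. Compound 3 is therefore expected to give about 20000 nM in this assay, with a range from 8000 nM to 50000 nM.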

Compound 3, half-maximal cytotoxic concentration: > 100000 nM
Compound 3: only a limit was reported; the forecaster's own chance of this, stated with the estimate: 25%; middle value at least 5.0-fold (0.69 log units) from the limit.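

In this assay, the exchange of furan-3-yl for pyridin-2-yl on a saturated chain carbon bound to an oxygen on a saturated carbon gives an at least 4.7-fold higher number from compound 2 to compound 3 (0.67 log units; beyond the scatter), and this higher number means lower toxicity in this test. Within the data shown here, this is the first single-place comparison, and it shows that the ring at this position alone can move the read-out beyond the scatter, even though the two groups count the same hydrogen-bond donors and acceptors and neither carries a net charge. Compound 3 has a limit of the assay and not a number, so the step gives only a lower bound on the change: the limit of > 100000 nM in this assay, at which 1 of the 3 values shown sits.

The compounds shown leave open whether the ring nitrogen, the ring size or the place of the hetero atom accounts for the step, a question that phenyl, pyridin-3-yl or pyridin-4-yl at this position would help to separate. They also leave open whether the same exchange would have a like effect on another core, such as that of compound 1, and what causes the step at all.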